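Swapping the halophenyl arm of a dienone core

This account rests on a few compounds, and the source may have more. Where it says the series, first, only, none or still open, it means among the compounds named here.

Measured compounds:
Compound 1: `COc1cccc(/C=C2\CCC/C(=C\c3cccc(Cl)c3)C2=O)c1OC` with 9100 nM
Compound 2: `COc1cccc(/C=C2\CCC/C(=C\c3cccc(Br)c3)C2=O)c1OC` with 8800 nM

The two measured compounds share a core and differ only in the aryl group on one exocyclic double bond. In a functional assay on SW-620 cells (Homo sapiens) for cytotoxicity, read by MTT assay, with a stated time of 72 h (on this read-out higher numbers stand for weaker inhibition and lower numbers for stronger inhibition), compound 1 gives 9100 nM, and compound 2 gives 8800 nM. Going by the values given here, the step of a 1.0-fold lower number from compound 1 to compound 2 (0.01 log units; within the scatter) is the only measured step, and it lies within the scatter. Compound 2 therefore stands with the lowest of the two numbers, but its distance from compound 1 is too small to call it stronger.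

The unmeasured compound 3 is `COc1cccc(/C=C2\CCC/C(=C\c3ccc(Cl)cc3Cl)C2=O)c1OC`. It differs from compound 2 by 2,4-dichlorophenyl in place of 3-bromophenyl on a double-bonded chain carbon bound to a double-bonded ring carbon. Among the compounds with values here, no measured step covers this kind of change: the only step at hand, a 1.0-fold lower number from compound 1 to compound 2 (0.01 log units; within the scatter), exchanges one halogen for another at the same place and shows nothing beyond the scatter. Within the data shown here, with that as the sole guide, any movement in this assay is expected to be modest, and the number for compound 3 is estimated at 7000 nM, within 2500 nM to 20000 nM. This estimate means a step of a 1.3-fold lower number from compound 2 to compound 3 (0.10 log units; within the scatter), which is expected to stay near the scatter.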

Compound 3, half-maximal inhibitory concentration: 16300 nM
The estimate for compound 3 lay 2.3-fold (0.37 log units) below the measured number, and the stated range covers the measured number.
By their numbers in this assay, from the lowest: compounds 2, 1 and 3 (each within the scatter of the next).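

Exchanging the 3-bromophenyl or 3-chlorophenyl arm for 2,4-dichlorophenyl, on a double-bonded chain carbon bound to a double-bonded ring carbon, goes beyond the swap of one halogen for another, yet in this assay it gives a 1.9-fold higher number from compound 2 to compound 3 (0.27 log units; within the scatter) and a 1.8-fold higher number from compound 1 to compound 3 (0.25 log units; within the scatter). The earlier pair spoke only to a single halogen exchange on the arm, whereas these steps add a change in the number of halogens and in the pattern of substitution, and neither step leaves the scatter. This place has now carried three halophenyl groups with no printed step among them beyond the scatter, so the three compounds cannot be ranked against one another, and no measurement is at hand that would explain their numbers.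

The compounds shown leave open whether a phenyl ring carrying an amine or a carboxylic acid at this place would produce a step beyond the scatter, as every arm here carries only halogen. They also leave open what a change to the other aryl group would do, as that group is the same in all three compounds.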